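The compounds below may be only part of what the source reports. "The series", "measured", "known", "first", "only" and "open" are said of these compounds alone.

Measured in a functional assay on PC-3 cells (Homo sapiens) for antiproliferative activity, read by MTT assay, with a stated time of 24 h; a higher number here means a weaker inhibitor, a lower number a stronger inhibitor:
- Compound 1 `CCn1c(C(=O)NCCNC(=O)OC(C)(C)C)ccc1C(CC)(CC)c1ccc(OCS(=O)(=O)c2ccccc2)c(C)c1`: > 50000 nM (a limit)
- Compound 2 `CCn1c(C(=O)N[C@@H](CO)CCCO)ccc1C(CC)(CC)c1ccc(OCS(=O)(=O)c2ccccc2)c(C)c1`: 13400 nM

The reading for compound 1 is a limit of the assay and not a number, as the limit of > 50000 nM in this assay, at which 1 of the 2 values shown sits, records. For the measured compounds named here, compound 2 therefore holds the only true number so far, 13400 nM, and it is the stronger of the two.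

Compound 3 `CCn1c(C(=O)NCC(=O)O)ccc1C(CC)(CC)c1ccc(OCS(=O)(=O)c2ccccc2)c(C)c1` keeps the shared core of compound 2 and changes only the substituent on the amide-type nitrogen: a group of 4 heavy atoms (2 carbon, 2 oxygen; no ring) in place of a group of 7 heavy atoms (5 carbon, 2 oxygen; no ring), on an amide-type nitrogen. Carboxymethyl thus stands in place of the group of 7 heavy atoms.

Going by the values given here, one measured step bears on this change, because an at least 3.7-fold lower number from compound 1 to compound 2 (0.57 log units; beyond the scatter) was made at the same nitrogen. It shows that this place can move the number in this assay beyond the scatter, but it was made with a different pair of groups and does not settle the direction for carboxymethyl. A modest step of similar size towards a higher number, meaning a weaker inhibitor, is expected, though with little certainty. The expected change is a 1.9-fold higher number from compound 2 to compound 3 (0.27 log units; within the scatter). For compound 3 the estimated value is 25000 nM, with an expected range from 9000 nM to 70000 nM.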

Compound 3, half-maximal inhibitory concentration: 30100 nM
Compound 3: middle estimate off by 1.2-fold (0.08 log units), on the low side; the measured number falls inside the stated range.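

In this assay, for the compounds shown here, the change on the amide-type nitrogen gives a 2.2-fold higher number from compound 2 to compound 3 (0.35 log units; beyond the scatter): this is the first step at this place with a true number at both ends, so both its direction and its size can be read. It is a modest step, and it leaves compound 2, with its group of 7 heavy atoms and 1 defined stereocentre, the stronger of the pair, while carboxymethyl brings no gain. The comparison with the protected chain gives an at least 1.6-fold lower number from compound 1 to compound 3 (0.22 log units; that floor lies within the scatter), and this does not set compound 1 and compound 3 in order, as the reading for compound 1 is a limit and not a number: the limit of > 50000 nM in this assay, at which 1 of the 3 values shown sits.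

One change here replaces a whole group, so the compounds shown cannot separate the effect of chain length from that of the end groups, or show whether the defined stereocentre matters. Going by these compounds, how a methyl ester of the carboxymethyl group, a primary amine or a longer chain ending in a carboxylic acid would read on this nitrogen remains open.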